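Swapping a chlorinated ring for a difluorinated one

The compounds below may be only part of what the source reports. "The series", "measured", "known", "first", "only" and "open" are said of these compounds alone.

Measured compounds:
Compound 1 `Cc1ccc(S(=O)(=O)N(Cc2cn(Cc3ccccc3Cl)nn2)Cc2cn(S(=O)(=O)c3ccc(C)cc3)c3ccccc23)cc1` gives -4.8%.
Compound 2 `Cc1ccc(S(=O)(=O)n2cc(CN(Cc3ccccc3)Cc3cccc(F)c3F)c3ccccc32)cc1` gives -13.1%.
Compound 3 `Cc1ccc(S(=O)(=O)N(Cc2ccc(F)cc2)Cc2cccc(F)c2F)cc1` gives -97.7%.

These three compounds were tested in a functional assay on 3T3-L1 cells (Mus musculus) for inhibition, with a stated time of 20 min, tested at 20 uM; a higher number here means more inhibition at the concentration tested (going by the name of the read-out), a lower number less inhibition. Compound 1 gives the highest of the three numbers, -4.8%. Its nearest neighbour is compound 2 with -13.1%, a value within the scatter of repeated measurement, so the two cannot be ranked against each other. Compound 3, with -97.7%, lies far below both, a gap well beyond the scatter.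

For the measured compounds named here, no pair of the measured compounds differs in only one place, so no single-point step can be read off. The step considered here runs from compound 1 to compound 4 `Cc1ccc(S(=O)(=O)N(Cc2cn(Cc3ccc(F)cc3F)nn2)Cc2cn(S(=O)(=O)c3ccc(C)cc3)c3ccccc23)cc1`, an unmeasured compound. The difference is 2,4-difluorophenyl in place of 2-chlorophenyl on a saturated chain carbon bound to an aromatic nitrogen.

Going by the values given here, nothing among the measured compounds isolates the effect of exchanging one halogenated ring for another on that carbon. With compound 1 and compound 2 sitting within the scatter of each other and sharing a related architecture, the step in this assay from compound 1 to compound 4 is expected to be small, in neither direction beyond the scatter, so the estimate is a number 0.2 percentage points lower from compound 1 to compound 4 (within the scatter). Compound 4 is therefore expected to give about -5%, within a range of -35% to 25%.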

Compound 4, a percentage reported as inhibition, at one concentration (the size of the read-out at that concentration, not a potency): 12.3%
The estimate for compound 4 lay 17.3 percentage points below the measured number; low and high end bracket the measured number.
By their numbers in this assay, from the lowest: compound 3; then compounds 2 and 1 (each within the scatter of the next); then compound 4.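

In this assay, 2,4-difluorophenyl in place of 2-chlorophenyl on a saturated chain carbon bound to an aromatic nitrogen gives a number 17.1 percentage points higher from compound 1 to compound 4 (beyond the scatter). This is the first change in the set confined to one place, and its size, though modest, lies beyond the scatter, so the read-out at this position is shown to depend on which halogenated ring is present. With this change, compound 4 gives 12.3%, a positive number where compound 1 gives -4.8%, although no measurement at hand bears on why the number moves.

The change removes chlorine and brings in two fluorines at once, so the compounds shown do not separate the loss of the one from the gain of the other, and they do not show whether the step would hold on a different core. On these data alone, it also remains open how a phenyl ring carrying a methoxy group, an amine or a carboxylic acid in place of the halogens would read at this position, and, with only one concentration tested, how compound 4 would behave across a range of concentrations.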